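This account rests on a few compounds, and the source may have more. Where it says the series, first, only, none or still open, it means among the compounds named here.

Compound 1 `COc1cccc(-c2csc(NC(=O)c3ccc([N+](=O)[O-])o3)n2)c1` gives 58700 nM in an ADME assay on Vero cells (Chlorocebus sabaeus) for cytotoxicity, read by MTT assay, with a stated time of 72 h (on this read-out lower numbers stand for stronger inhibition and higher numbers for weaker inhibition), and compound 2 `O=C(Nc1nc(-c2cccc(Br)c2)cs1)c1ccc([N+](=O)[O-])o1` gives 71000 nM there, so the two stand within the scatter of each other and compound 1 stands nearest compound 2. Among the measured compounds shown here, the only step in hand, a 1.2-fold higher number from compound 1 to compound 2 (0.08 log units; within the scatter), changes a different part of the molecule and was itself within the scatter. Compound 3 `O=C(Nc1nc(-c2cccc(OC3CCCC3)c2)cs1)c1ccc([N+](=O)[O-])o1` differs from compound 1 by cyclopentyl in place of methyl on an oxygen on an aromatic ring. For the measured compounds named here, no measured step touches that oxygen substituent, so the expected step from compound 1 to compound 3 is set at a 1.2-fold lower number from compound 1 to compound 3 (0.07 log units; within the scatter), not beyond the scatter. The estimate for compound 3 in this assay is therefore 50000 nM, expected to fall between 20000 nM and 120000 nM.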

Compound 3, half-maximal inhibitory concentration: 81100 nM
Compound 3: middle estimate off by 1.6-fold (0.21 log units), on the low side, and the stated range covers the measured number.
By their numbers in this assay, from the lowest: compounds 1, 2 and 3 (each within the scatter of the next).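

In this assay, cyclopentyl in place of methyl on the oxygen gives a 1.4-fold higher number from compound 1 to compound 3 (0.14 log units; within the scatter) and so adds a ring at this position without a step beyond the scatter. Cyclopentyloxy in place of bromo on the aromatic carbon gives a 1.1-fold higher number from compound 2 to compound 3 (0.06 log units; within the scatter) and is likewise within the scatter, so methoxy, bromo and cyclopentyloxy read alike here. Nothing available explains this flat read-out.

As far as these compounds go, whether a group carrying an amine or a carboxylic acid at this position would give a step beyond the scatter stays open. The same holds for a longer chain on the oxygen.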